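Vero cytotoxicity notes on the shared core, compound 4

The source may report more compounds than this note shows. Statements on the series, on what has been measured and on what is new or still open speak of the compounds shown alone.

Compound 2 `CN(CC1CCCCC1)N1CCN(c2nc(=O)c3cc(C(F)(F)F)cc([N+](=O)[O-])c3s2)CC1` is the starting point. In an ADME assay on Vero cells (Chlorocebus sabaeus) for cytotoxicity, read by MTT assay, with a stated time of 72 h (on this read-out lower numbers stand for higher toxicity in this test and higher numbers for lower toxicity in this test), compound 2 gives > 64 ug/mL, which is a limit of the assay and not a number. Compound 1 `O=c1nc(N2CCN(NC3CCCCC3)CC2)sc2c([N+](=O)[O-])cc(C(F)(F)F)cc12` is likewise held at a limit, with > 64 ug/mL in this assay. Compound 3 `O=c1nc(N2CCN(NCc3ccc(Br)cc3)CC2)sc2c([N+](=O)[O-])cc(C(F)(F)F)cc12` also sits at a limit, giving > 64 ug/mL in this assay. Accordingly (the limit of > 64 ug/mL in this assay, at which 3 of the 3 values shown sit), and the steps a step that the two limits leave unreadable from compound 1 to compound 2, a step that the two limits leave unreadable from compound 1 to compound 3 and a step that the two limits leave unreadable from compound 2 to compound 3 cannot be read. Compound 4 `O=c1nc(N2CCN(Nc3ccc(OC(F)(F)F)cc3)CC2)sc2c([N+](=O)[O-])cc(C(F)(F)F)cc12` differs from compound 2 by (4-(trifluoromethoxy)phenyl)amino in place of (cyclohexylmethyl)(methyl)amino on an amine nitrogen in a ring. The measured steps bear on it only in that every change at this ring nitrogen left the value at the limit, so no step beyond the scatter is expected in this assay, with a step that the limit leaves unreadable from compound 2 to compound 4 as the expected step. Compound 4 is expected to give 80 ug/mL in this assay, within 40 ug/mL to 200 ug/mL.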

Compound 4, half-maximal cytotoxic concentration: > 64 ug/mL
Compound 4 ended at the assay's limit; the forecaster's own chance of this, stated with the estimate: 75%; the middle value is on the limit's open side.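

Compound 4 also sits at a limit, so no step from compound 1, compound 2 or compound 3 to compound 4 can be read: the limit of > 64 ug/mL in this assay, at which 4 of the 4 values shown sit.

The compounds shown leave open whether any change on this ring nitrogen moves the read-out at all.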